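The compounds below may be only part of what the source reports. "The series", "measured", "known", "first", "only" and "open" are said of these compounds alone.

Among the compounds with values here, in a toxicity assay on microsomes from liver (Homo sapiens) for metabolic stability, read by LC-MS, using NADPH, tested at 1 uM (on this read-out higher numbers stand for fast clearance and lower numbers for slow clearance), the series so far runs from compound 1 (`CCOc1ncc(-c2nc(C(F)(F)F)sc2N2CCN(C(=O)Cn3ccc4cnccc43)[C@H](C)C2)cn1`) with 656 mL.min-1.g-1 down through compound 2 (`CCOc1ncc(-c2nc(C(F)(F)F)sc2N2CCN(C(=O)Cn3ncc4cccnc43)[C@H](C)C2)cn1`) with 41 mL.min-1.g-1 to compound 3 (`CCOc1ncc(-c2nc(C(F)(F)F)sc2N2CCN(C(=O)Cn3ccc(C(F)(F)F)n3)[C@H](C)C2)cn1`) with 20 mL.min-1.g-1 as the lowest of the three numbers. Compound 4 (`CCOc1ncc(-c2nc(C(F)(F)F)sc2N2CCN(C(=O)Cn3cnc(C(F)(F)F)n3)[C@H](C)C2)cn1`) is still to be measured. Within the data shown here, the only change from compound 3 is 3-(trifluoromethyl)-1H-1,2,4-triazol-1-yl in place of 3-(trifluoromethyl)-1H-pyrazol-1-yl on a saturated chain carbon bound to a carbonyl carbon and the rest of the structure stays the same.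

Three measured steps fall at this same place. The large 16-fold lower number from compound 1 to compound 2 (1.20 log units; beyond the scatter) and the large 33-fold lower number from compound 1 to compound 3 (1.52 log units; beyond the scatter) both start from the high number of compound 1 and exchange a whole group, so they say little about a single ring atom. The modest 2.1-fold lower number from compound 2 to compound 3 (0.31 log units; beyond the scatter) is the closest in size to what a change this small might give. The ring nitrogen count gives no clean direction: compound 2 has more ring nitrogen than compound 1 and a lower number, yet compound 3 has less than compound 2 and also a lower number. Among the measured compounds shown here, no measured step isolates the exchange of one ring carbon for a ring nitrogen.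

A small change is therefore expected in this assay, with no step beyond the scatter and a slight lean to a lower number. The expected step is a 1.3-fold lower number from compound 3 to compound 4 (0.12 log units; within the scatter) in this read-out. Compound 4 is estimated at 15 mL.min-1.g-1 (expected range 7 mL.min-1.g-1 to 32 mL.min-1.g-1).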

Compound 4, intrinsic clearance in microsomes: < 10 mL.min-1.g-1
Compound 4: a limit, no number; the forecaster's own chance of this, stated with the estimate: 10%; at least 1.5-fold (0.17 log units) between middle value and limit.
By their numbers in this assay, from the lowest: compound 3; then compound 2; then compound 1. At a limit, below all of these: compound 4.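

In this assay compound 4 gives a limit of the assay and not a number: the limit of < 10 mL.min-1.g-1 in this assay, at which 1 of the 4 values shown sits.

Within the data shown here, the exchange of 3-(trifluoromethyl)-1H-pyrazol-1-yl for 3-(trifluoromethyl)-1H-1,2,4-triazol-1-yl on a saturated chain carbon bound to a carbonyl carbon gives an at least 2.0-fold lower number from compound 3 to compound 4 (0.30 log units; that floor lies within the scatter), the first step at this position that isolates a ring carbon going to a ring nitrogen; the number does not rise, but the floor of the step does not by itself clear the scatter. Against the fused bicyclic groups, the whole-group exchanges give an at least 4.1-fold lower number from compound 2 to compound 4 (0.61 log units; beyond the scatter) and an at least 65-fold lower number from compound 1 to compound 4 (1.81 log units; beyond the scatter), both printed as beyond the scatter, so the trifluoromethyl triazolyl group keeps the low clearance reached with the trifluoromethyl pyrazolyl group.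

From the compounds shown here alone, how far compound 4 lies under its limit stays open, and with it the true size of the step from the pyrazolyl group. Also open, going by these compounds, is whether the low reading in this assay holds with a methyl group or a nitrile in place of the trifluoromethyl on the same triazolyl ring.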